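From 4-methoxyphenyl to 3,5-dichlorophenyl on the sulfonamide nitrogen

This account rests on a few compounds, and the source may have more. Where it says the series, first, only, none or still open, it means among the compounds named here.

Compound 1 (`CCCN(CCC)c1c([N+](=O)[O-])cc(S(=O)(=O)Nc2ccc(OC)cc2)cc1[N+](=O)[O-]`) is the starting point for this step. Within the data shown here, in a functional assay on PC-3 cells (Mus musculus) for cytotoxicity against PC-3 (Homo sapiens) (on this read-out higher numbers stand for weaker inhibition and lower numbers for stronger inhibition), compound 1 gives 31000 nM as the higher of the two numbers measured so far. Compound 2 (`CCCN(CCC)c1c([N+](=O)[O-])cc(S(=O)(=O)Nc2ccc(Cl)c(Cl)c2)cc1[N+](=O)[O-]`) gives 15000 nM in this assay as well. Among the measured compounds shown here, compound 3 (`CCCN(CCC)c1c([N+](=O)[O-])cc(S(=O)(=O)Nc2cc(Cl)cc(Cl)c2)cc1[N+](=O)[O-]`) has no measurement yet. Relative to compound 1, it carries 3,5-dichlorophenyl in place of 4-methoxyphenyl on a sulfonamide nitrogen.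

For the measured compounds named here, only one measured step bears on this change: a 2.1-fold lower number from compound 1 to compound 2 (0.32 log units; beyond the scatter) with 3,4-dichlorophenyl in place of the same 4-methoxyphenyl on the same nitrogen. That step is modest, though beyond the scatter. Going by the values given here, no measured compound carries 3,5-dichlorophenyl, so the comparison is indirect and rests on a single pair. A step of similar modest size toward a lower number is therefore expected in this assay for compound 3. The estimated change is a 2.1-fold lower number from compound 1 to compound 3 (0.32 log units; beyond the scatter) with a wide margin on either side. Compound 3 is estimated at 15000 nM (expected range 7000 nM to 32000 nM).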

Compound 3, half-maximal inhibitory concentration: 11000 nM
Estimate against measurement, compound 3: 1.4-fold (0.13 log units) above; the measured number falls inside the stated range.
By their numbers in this assay, from the lowest: compounds 3 and 2 (each within the scatter of the next); then compound 1.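

In this assay, 3,5-dichlorophenyl on the sulfonamide nitrogen gives a 2.8-fold lower number from compound 1 to compound 3 (0.45 log units; beyond the scatter) and so joins 3,4-dichlorophenyl, which gives a 2.1-fold lower number from compound 1 to compound 2 (0.32 log units; beyond the scatter), on the same side of compound 1. Moving between the two dichlorophenyl groups gives a 1.4-fold lower number from compound 2 to compound 3 (0.13 log units; within the scatter), so on this read-out the series does not separate the two chlorine arrangements, and the gain over 4-methoxyphenyl is seen with both of them. No supporting data bear on the origin of these differences, so the series records the change in the numbers without an explanation.

The three compounds do not show whether the lower numbers go with the entry of the chlorine atoms or with the departure of the 4-methoxyphenyl group; unsubstituted phenyl or 4-chlorophenyl on the same nitrogen would bear directly on that question. Going by these compounds, the shared core is constant throughout, so it also remains open how a change away from this nitrogen, such as a carboxylic acid on the aryl ring or a longer chain on the core's amine, would combine with either dichlorophenyl group.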